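The source may report more compounds than this note shows. Statements on the series, on what has been measured and on what is new or still open speak of the compounds shown alone.

Measured so far:
compound 1 `C#CCOc1cccc(/C=C/C(=O)Nc2cc(C(=O)c3cc(OC)c(OC)c(OC)c3)ccc2OC)c1` gives 13400 nM
compound 2 `COc1ccc(C(=O)c2cc(OC)c(OC)c(OC)c2)cc1NC(=O)/C=C/c1ccc(F)cc1` gives 3400 nM

In a functional assay on COLO 205 cells (Homo sapiens) for cytotoxicity, read by MTT assay, with a stated time of 72 h (on this read-out higher numbers stand for weaker inhibition and lower numbers for stronger inhibition), compound 2 stands lowest of the two numbers shown, and its nearest neighbour is compound 1, which differs only in the aromatic ring attached to the double-bonded chain; that one step was a 3.9-fold lower number from compound 1 to compound 2 (0.60 log units; beyond the scatter). The next compound, compound 3 `COc1cc(C(=O)c2cc(OC)c(OC)c(OC)c2)cc(NC(=O)/C=C/c2ccc(F)cc2)c1OC`, keeps the whole of compound 2 and carries one change: methoxy in place of hydrogen on an aromatic carbon, the new methoxy sitting ortho to a methoxy group already on the core and meta to the ((2-(4-fluorophenyl)ethenyl)carbonyl)amino group.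

Among the compounds with values here, no measured step touches this kind of change. Within the data shown here, the only step on record, from compound 1 to compound 2, swaps the aryl group at the far end of the chain and says nothing about adding a methoxy to the core ring. With nothing to lean on, the step in this assay from compound 2 to compound 3 is expected to stay within the scatter, with a wide margin of doubt in either direction; the expected step is a 1.2-fold higher number from compound 2 to compound 3 (0.07 log units; within the scatter). Compound 3 is therefore estimated at 4000 nM, within a range of 1000 nM to 16000 nM.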

Compound 3, half-maximal inhibitory concentration: 3100 nM
For compound 3 the middle estimate is 1.3-fold (0.11 log units) above the measured one; measured number inside the range.
By their numbers in this assay, from the lowest: compounds 3 and 2 (each within the scatter of the next); then compound 1.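

In this assay, a methoxy placed on the aromatic carbon ortho to a methoxy group and meta to the ((2-(4-fluorophenyl)ethenyl)carbonyl)amino group gives a 1.1-fold lower number from compound 2 to compound 3 (0.04 log units; within the scatter) and so leaves the read-out within the usual scatter. Within the data shown here, the earlier step changed only the aromatic group at the far end of the chain, so this is the first sign that the shared core can carry one more methoxy at this position with no measurable change in cytotoxicity, here with 4-fluorophenyl at the end of the chain. Nothing measured here bears on this outcome.

As far as these compounds go, it remains open whether a different group on this same carbon, such as a hydroxyl, an amine or a longer ethoxy chain, would also stay within the scatter or would move the number in either direction. From the compounds shown here alone, it is also open whether the added methoxy would give the same result with the 3-(propargyloxy)phenyl group of compound 1 at the end of the chain.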